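A few compounds are considered here, and "the series" means these few. Any claim that something is new, unique, unknown or untested is made for them only; others in the source may bear on it.

In a functional assay on A549 cells (Homo sapiens) for inhibition, read by sulforhodamine B assay, with a stated time of 72 h (a lower number here means a stronger inhibitor of growth, a higher number a weaker inhibitor of growth), compound 3 `CCOC(=O)/C=C/c1ccncc1-c1ccc2cc[nH]c2c1` gives 5740 nM, compound 2 `CCOC(=O)/C=C/c1ccncc1-c1ccc2ccccc2c1` gives 5380 nM and compound 1 `CNC(=O)/C=C/c1ccncc1-c1ccc2cc[nH]c2c1` gives 7840 nM. These three values all lie within the scatter of one another, so compound 3 is not separated from either neighbour. Compound 4 `O=C(/C=C/c1ccncc1-c1ccc2cc[nH]c2c1)N1CCOCC1` differs from compound 3 as follows: morpholin-4-yl in place of ethoxy on a carbonyl carbon. In words, this is morpholin-4-yl in place of ethoxy on a carbonyl carbon. Among the measured compounds shown here, the only measured step at this carbonyl carbon is a 1.4-fold lower number from compound 1 to compound 3 (0.14 log units; within the scatter), with ethoxy in place of methylamino, and it stays within the scatter. For the measured compounds named here, no morpholin-4-yl compound has been measured yet, so a step beyond the scatter is not expected in this assay. The expected step is a 1.1-fold higher number from compound 3 to compound 4 (0.05 log units; within the scatter). For compound 4 the estimate is 6500 nM, with an expected range of 3300 nM to 13000 nM.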

Compound 4, concentration for 50% growth inhibition: > 10000 nM
Compound 4 ended at the assay's limit; the forecaster's own chance of this, stated with the estimate: 10%; at least 1.5-fold (0.18 log units) between middle value and limit.
By their numbers in this assay, from the lowest: compounds 2, 3 and 1 (each within the scatter of the next). At a limit, above all of these: compound 4.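

In this assay compound 4 gives > 10000 nM, a limit of the assay and not a number. On this carbonyl carbon, morpholin-4-yl gives the steps of an at least 1.7-fold higher number from compound 3 to compound 4 (0.24 log units; that floor lies within the scatter) and an at least 1.2-fold higher number from compound 1 to compound 4 (0.10 log units; that floor lies within the scatter), so a six-membered ring here is not yet shown to differ from ethoxy or methylamino. It is, however, the first change at this place to reach the limit: the limit of > 10000 nM in this assay, at which 1 of the 4 values shown sits.

Still open, on these data alone, is the true value of compound 4. Also open, as far as these compounds go, is whether piperazin-1-yl, a free amine or a longer alkoxy chain on this carbonyl carbon gives a step beyond the scatter.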